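This account rests on a few compounds, and the source may have more. Where it says the series, first, only, none or still open, it means among the compounds named here.

Measured in a physicochemical assay for permeability, using PAMPA; a lower number here means that the compound crosses the layer more slowly, a higher number that the compound crosses the layer faster:
- Compound 1 `Cc1ccccc1-c1nc(CN2CCC(C(=O)NCCCN3CCC(C)(C)CC3)CC2)c(C)o1`: 241 10^-6 cm/s
- Compound 2 `Cc1oc(-c2ccc(Cl)cc2)nc1CN1CCC(C(=O)NCCCN2C[C@H](C)C[C@H](C)C2)CC1`: > 635 10^-6 cm/s (a limit, not a number)
- Compound 3 `Cc1ccccc1-c1nc(CN2CCC(C(=O)NCCCN3CCC(C)CC3)CC2)c(C)o1`: 425 10^-6 cm/s

Compound 2 gives > 635 10^-6 cm/s, which is a limit of the assay and not a number. Compound 4 `Cc1oc(-c2c(F)cccc2F)nc1CN1CCC(C(=O)NCCCN2C[C@H](C)C[C@H](C)C2)CC1` has not been measured. It carries 2,6-difluorophenyl in place of 4-chlorophenyl on an aromatic carbon. Among the compounds with values here, no measured step covers this change. Within the data shown here, the only step available is a different one, hydrogen in place of methyl on a saturated ring carbon: a 1.8-fold higher number from compound 1 to compound 3 (0.25 log units; within the scatter). Among the measured compounds shown here, with only that step to go on, no step beyond the scatter is expected in this assay, and the direction stays open. The estimated step is an at least 1.3-fold lower number from compound 2 to compound 4 (0.12 log units; that floor lies within the scatter). For compound 4 the estimated value is 480 10^-6 cm/s, with an expected range from 200 10^-6 cm/s to 900 10^-6 cm/s.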

Compound 4, apparent permeability: 82.4 10^-6 cm/s
Compound 4: the middle estimate sits 5.8-fold (0.77 log units) above what was measured; measured number below the stated range.
By their numbers in this assay, from the lowest: compound 4; then compounds 1 and 3 (each within the scatter of the next). At a limit, above all of these: compound 2.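

In this assay, placing 2,6-difluorophenyl where 4-chlorophenyl stood gives an at least 7.7-fold lower number from compound 2 to compound 4 (0.88 log units; beyond the scatter). The only earlier step, a 1.8-fold higher number from compound 1 to compound 3 (0.25 log units; within the scatter), came from a saturated ring carbon, so this is the first change shown that moves the number beyond the scatter. Compound 2 stands at a limit of the assay, not a number, so this step is only a floor: the limit of > 635 10^-6 cm/s in this assay, at which 1 of the 4 values shown sits. Still open, from the compounds shown here alone, is whether losing the chlorine or gaining the two fluorines matters more; a plain phenyl group at this position would help separate the two.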